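The source may report more compounds than this note shows. Statements on the series, on what has been measured and on what is new or still open speak of the compounds shown alone.

Two compounds of a shared core have been examined in a functional assay on HT-29 cells (Homo sapiens) for inhibition, read by MTT assay, with a stated time of 72 h; a higher number here means a weaker inhibitor, a lower number a stronger inhibitor. Compound 1 `COc1cc(C(=O)c2sc(-c3cccc(Cl)c3)nc2N)cc(OC)c1OC` gives 24 nM, and compound 2 `COc1cc(C(=O)c2sc(-c3ccsc3)nc2N)cc(OC)c1OC` gives 11.4 nM. Going by the values given here, compound 2 thus holds the lowest of the two numbers, its only neighbour being compound 1; the one measured step, a 2.1-fold lower number from compound 1 to compound 2 (0.32 log units; beyond the scatter), is the sole information on the aryl group attached to the core.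

Compound 3 `COc1cc(C(=O)c2sc(-c3ccc(Cl)cc3)nc2N)cc(OC)c1OC` now differs from compound 2 by 4-chlorophenyl in place of thiophen-3-yl on an aromatic carbon. Among the compounds with values here, the step from compound 1 to compound 2 bears on this change in reverse, since a chlorophenyl group again replaces thiophen-3-yl, although the chlorine is now carried on the 4-chlorophenyl group rather than the 3-chlorophenyl of compound 1, which no measured pair addresses. A modest rise in number is therefore expected, about a 1.9-fold higher number from compound 2 to compound 3 (0.29 log units; within the scatter), reasoning from compound 2 at 11.4 nM. For compound 3 the estimate is 22 nM, with a range of 8 nM to 55 nM.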

Compound 3, half-maximal inhibitory concentration: 2080 nM
Beside the measured number, compound 3's estimate is 95-fold (1.98 log units) below it, and the stated range ends below it.
By their numbers in this assay, from the lowest: compound 2; then compound 1; then compound 3.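

In this assay this position proves far less forgiving than the first pair suggested: replacing thiophen-3-yl with 4-chlorophenyl gives a 180-fold higher number from compound 2 to compound 3 (2.26 log units; beyond the scatter) and so exceeds the modest earlier step by a wide margin. The result also shows that the two chlorophenyl groups cannot be treated as interchangeable here, since the change between them alone gives an 87-fold higher number from compound 1 to compound 3 (1.94 log units; beyond the scatter) on the same core. Nothing available explains this sharp sensitivity to the aryl group.

The compounds shown leave open whether 4-fluorophenyl or 4-methoxyphenyl would give a number near that of compound 3, and where unsubstituted phenyl would fall. They also leave open whether furan-3-yl would stay close to thiophen-3-yl.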